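Hydrazone aryl swap on the shared core: cytotoxicity notes

This account rests on a few compounds, and the source may have more. Where it says the series, first, only, none or still open, it means among the compounds named here.

Compound 1 `O=C(CSc1nnnn1-c1cccc2ccccc12)N/N=C/c1cccs1` carries thiophen-2-yl on the carbon with a double bond to nitrogen. In an ADME assay on MT4 cells (Homo sapiens) for cytotoxicity, read by MTT assay (a lower number here means that less compound is tolerated, a higher number that more compound is tolerated), compound 1 gives only a limit of the assay, > 316000 nM, so its true value is not pinned down. For the measured compounds named here, compound 2 `O=C(CSc1nnnn1-c1cccc2ccccc12)N/N=C/c1ccccc1Cl` is the one measured neighbour: in this assay compound 2 gives 69700 nM. Going by the values given here, the step of an at least 4.5-fold lower number from compound 1 to compound 2 (0.65 log units; beyond the scatter) is the only measured change at this position, and its size is itself bounded by the limit of > 316000 nM in this assay, at which 1 of the 2 values shown sits, rather than fixed.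

Compound 3 `COc1ccc(/C=N/NC(=O)CSc2nnnn2-c2cccc3ccccc23)cc1` differs from compound 1 by the change (4-methoxyphenyl in place of thiophen-2-yl on a carbon with a double bond to nitrogen). Among the compounds with values here, the only comparison that bears on it is the step from compound 1 to compound 2, where a six-membered carbon ring replaced the thiophen-2-yl and the number fell by at least a modest amount. A drop of similar order is therefore expected here, though the open-ended starting point of compound 1 leaves the outcome broad. Compound 3 is expected to give 150000 nM in this assay, with a range of 50000 nM to 400000 nM. That estimate means an expected step of an at least 2.1-fold lower number from compound 1 to compound 3 (0.32 log units; beyond the scatter).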

Compound 3, half-maximal cytotoxic concentration: > 298000 nM
Compound 3: a limit, no number; the forecaster's own chance of this, stated with the estimate: 35%; at least 1.9-fold (0.29 log units) between middle value and limit.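

Compound 3 gives only a limit of the assay in this assay, not a number: the limit of > 298000 nM in this assay, at which 1 of the 3 values shown sits. For the compounds shown here, putting 4-methoxyphenyl in place of 2-chlorophenyl on the carbon with a double bond to nitrogen gives an at least 4.2-fold higher number from compound 2 to compound 3 (0.63 log units; beyond the scatter) and shows that a six-membered carbon ring at this place does not by itself bring the lower number seen for compound 2, which is now the only one of the three compounds with a measured value. Compound 1 also stands at a limit of the assay, and the step from compound 1 to compound 3 cannot be read: the limit of > 316000 nM in this assay, at which 1 of the 3 values shown sits.

From the compounds shown here alone, how far the true values of compound 1 and compound 3 lie past their limits remains open, and so does any order between thiophen-2-yl and 4-methoxyphenyl in this assay. Also open, going by these compounds, is whether the lower number of compound 2 goes with the chlorine itself, and how an aryl group carrying an amine or a carboxylic acid would read at this place on the shared core.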